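The source may report more compounds than this note shows. Statements on the series, on what has been measured and on what is new or still open speak of the compounds shown alone.

Values in a functional assay on HeLa cells (Homo sapiens) for antiproliferative activity, read by cell counting, with a stated time of 72 h; a higher number here means a weaker inhibitor, a lower number a stronger inhibitor:
Compound 1 `C#C[C@@]1(O)[C@@H](CO)O[C@@H](n2cnc3c(-c4ccc(C)cc4)ncnc32)[C@@H]1O`: > 250000 nM, a limit.
Compound 2 `C#C[C@@]1(O)[C@@H](CO)O[C@@H](n2cnc3c(-c4ccc(Cl)cc4)ncnc32)[C@@H]1O`: 170000 nM.
Compound 3 `C#C[C@@]1(O)[C@@H](CO)O[C@@H](n2cc(F)c3c(N)ncnc32)[C@@H]1O`: 150 nM.

Compound 3, at 150 nM, has the lowest number shown, far from compound 2 at 170000 nM. Compound 4 `C#C[C@@]1(O)[C@@H](CO)O[C@@H](n2cc(Br)c3c(N)ncnc32)[C@@H]1O` differs from compound 3 by bromo in place of fluoro on an aromatic carbon. Within the data shown here, the only measured step is an at least 1.4-fold lower number from compound 1 to compound 2 (0.16 log units; that floor lies within the scatter). That chloro-for-methyl change rests on the limit of > 250000 nM in this assay, at which 1 of the 3 values shown sits, and occurs on a different group, so it gives little guidance on size. In this assay, only a modest rise, close to the scatter, is therefore expected, as the estimated 1.7-fold higher number from compound 3 to compound 4 (0.22 log units; within the scatter). The estimate for compound 4 is 250 nM, with an expected range of 40 nM to 2500 nM.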

Compound 4, half-maximal inhibitory concentration: 93 nM
For compound 4 the middle estimate is 2.7-fold (0.43 log units) above the measured one, and the stated range covers the measured number.
By their numbers in this assay, from the lowest: compounds 4 and 3 (each within the scatter of the next); then compound 2. At a limit, above all of these: compound 1.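

In this assay, the exchange of fluoro for bromo on an aromatic carbon of the five-membered aromatic ring gives a 1.6-fold lower number from compound 3 to compound 4 (0.21 log units; within the scatter), so the two groups cannot be told apart at this position. Among these compounds, the earlier compounds offered no step at this position, and the only earlier step, on a different group, rested on a limit. No measured property given here bears on this step.

Still open, on these data alone, is whether an amine, a nitrile or a methyl at this position would keep the number in the same range. Also open, as far as these compounds go, is whether plain hydrogen there would do so.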